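The compounds below may be only part of what the source reports. "The series", "measured", "known", "first", "only" and "open" are said of these compounds alone.

In a functional assay on MCF7 cells (Homo sapiens) for inhibition, with a stated time of 48 h (on this read-out higher numbers stand for weaker inhibition and lower numbers for stronger inhibition), compound 1 `COc1cc(Sc2c[nH]c3ccccc23)cc(OC)c1OC` gives 34 nM, compound 2 `COc1cc(Sc2c[nH]c3ccc(Cl)cc23)cc(OC)c1OC` gives 77 nM and compound 3 `COc1cc(Sc2c[nH]c3ccc(F)cc23)cc(OC)c1OC` gives 160 nM, the highest of the three numbers and so the weakest inhibition in this small set. The next change leads to compound 4 `COc1cc(Sc2c[nH]c3ccc([N+](=O)[O-])cc23)cc(OC)c1OC`: nitro in place of fluoro on an aromatic carbon. Among the compounds with values here, the steps that bear on this change are the replacements on the same carbon: a 2.3-fold higher number from compound 1 to compound 2 (0.36 log units; beyond the scatter), a 4.7-fold higher number from compound 1 to compound 3 (0.67 log units; beyond the scatter) and a 2.1-fold higher number from compound 2 to compound 3 (0.32 log units; beyond the scatter). All three are modest and beyond the scatter. Within the data shown here, no measured step has nitro entering, so these steps offer only indirect guidance. Both measured substituents give higher numbers than compound 1 at 34 nM, so a modest step towards a higher number is expected in this assay, with the direction uncertain. The expected step is a 1.6-fold higher number from compound 3 to compound 4 (0.19 log units; within the scatter). For compound 4 the estimated value is 250 nM, with an expected range of 60 nM to 1000 nM.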

Compound 4, half-maximal inhibitory concentration: 560 nM
Compound 4: the middle estimate sits 2.2-fold (0.35 log units) below what was measured, within the range that was stated.
By their numbers in this assay, from the lowest: compound 1; then compound 2; then compound 3; then compound 4.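

In this assay, nitro on this aromatic carbon gives a larger rise than either halogen, with a 3.5-fold higher number from compound 3 to compound 4 (0.54 log units; beyond the scatter) and a 7.3-fold higher number from compound 2 to compound 4 (0.86 log units; beyond the scatter) among the replacements of one substituent by another. Measured against the unsubstituted core, a 16-fold higher number from compound 1 to compound 4 (1.22 log units; beyond the scatter) is the first large step at this position, and all three groups shown here, chloro, fluoro and nitro, give higher numbers than hydrogen. Nothing available accounts for the size of the nitro step or for the order of the four compounds.

On these data alone, whether an amine, a methoxy group or a carboxylic acid on the same carbon would also give a higher number than compound 1 remains open, so it is unknown whether any replacement of hydrogen here can give a lower one. As far as these compounds go, the effect of changes elsewhere on the shared core also remains open.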